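Furan-3-yl for thiophen-2-yl on compound 2

The source may hold more compounds than are shown below. What is called first, only, known or untested is meant among the compounds shown, and "the series" means these compounds.

In a functional assay on BXPC-3 cells (Homo sapiens) for antiproliferative activity, read by sulforhodamine B assay, with a stated time of 72 h (a higher number here means a weaker inhibitor, a lower number a stronger inhibitor), compound 1 (`CC(C)(C)c1[nH]cnc1/C=c1\[nH]c(=O)/c(=C/c2cccc(C(=O)N3CCCCC3)c2)[nH]c1=O`) gives 100 nM as the higher number. Compound 2 (`CC(C)(C)c1[nH]cnc1/C=c1\[nH]c(=O)/c(=C/c2cccc(C(=O)c3cccs3)c2)[nH]c1=O`) stands lowest of the two measured compounds at 1.72 nM in this series. Going by the values given here, the one measured step is a 58-fold lower number from compound 1 to compound 2 (1.76 log units; beyond the scatter) and it places thiophen-2-yl where piperidin-1-yl stood on a carbonyl carbon. Compound 3 (`CC(C)(C)c1[nH]cnc1/C=c1\[nH]c(=O)/c(=C/c2cccc(C(=O)c3ccoc3)c2)[nH]c1=O`) carries furan-3-yl in place of thiophen-2-yl on that carbonyl carbon: furan-3-yl in place of thiophen-2-yl on a carbonyl carbon here. Both groups are five-membered aromatic rings, so the large step in a 58-fold lower number from compound 1 to compound 2 (1.76 log units; beyond the scatter) offers only a loose guide. The expected step is a 1.7-fold higher number from compound 2 to compound 3 (0.24 log units; within the scatter) and it is expected to stay close to the scatter. For compound 3 the estimate is 3 nM with an expected range of 1 nM to 10 nM in this assay overall.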

Compound 3, half-maximal inhibitory concentration: 9.41 nM
Estimate against measurement, compound 3: 3.1-fold (0.50 log units) below; the measured number falls inside the stated range.
By their numbers in this assay, from the lowest: compound 2; then compound 3; then compound 1.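

The step of a 5.5-fold higher number from compound 2 to compound 3 (0.74 log units; beyond the scatter) shows that on this carbonyl carbon the identity of the five-membered aromatic ring matters, even though both rings have the same heavy-atom count. The step of an 11-fold lower number from compound 1 to compound 3 (1.03 log units; beyond the scatter) shows that furan-3-yl still stands well clear of piperidin-1-yl, so compound 1 remains the highest of the three. Nothing available accounts for the gap between thiophen-2-yl and furan-3-yl.

Hetero atom and attachment point change together in this swap, and furan-2-yl or thiophen-3-yl would separate them. From the compounds shown here alone, how a phenyl ring would compare on this carbonyl carbon also remains open.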